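A few compounds are considered here, and "the series" means these few. Any claim that something is new, unique, unknown or untested is made for them only; others in the source may bear on it.

Values measured in a functional assay on HeLa cells (Homo sapiens) for antiproliferative activity, read by MTT assay, with a stated time of 48 h (a higher number here means a weaker inhibitor, a lower number a stronger inhibitor), so far:

Compound 1 `Oc1ccc2ccccc2c1C(Nc1nc2ccc(Cl)cc2s1)c1cn(-c2ccccc2)nc1-c1ccc(Cl)cc1` gives 36800 nM
Compound 2 `Oc1ccc2ccccc2c1C(Nc1nc2ccc(Cl)cc2s1)c1cn(-c2ccccc2)nc1-c1cccc(Cl)c1` gives 18300 nM

Compound 2 lies within the scatter of compound 1, so these two numbers cannot be ranked, and they are the only reference points available. Compound 3 `Oc1ccc2ccccc2c1C(Nc1nc2ccc(Cl)cc2s1)c1cn(-c2ccccc2)nc1-c1ccccc1` has not yet been measured. It keeps the shared core of compound 2 and differs in one place, where the 3-chlorophenyl becomes phenyl. That is hydrogen in place of chloro on an aromatic carbon and nothing else changes.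

Among the measured compounds shown here, only one measured step bears on this. Putting 3-chlorophenyl in place of 4-chlorophenyl gave a 2.0-fold lower number from compound 1 to compound 2 (0.30 log units; within the scatter) and so stayed within the scatter. For the measured compounds named here, that step moved the chloro group without removing it, and no measured compound shows what removal does. On this thin evidence, no change beyond the scatter is expected, and no direction can be argued firmly. The expected step is a 1.2-fold higher number from compound 2 to compound 3 (0.08 log units; within the scatter) as a rough estimate. Estimated for compound 3 in this assay is 22000 nM with a range from 8000 nM to 60000 nM as the expected span.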

Compound 3, half-maximal inhibitory concentration: 12500 nM
Compound 3: the middle estimate sits 1.8-fold (0.25 log units) above what was measured, within the range that was stated.
By their numbers in this assay, from the lowest: compounds 3, 2 and 1 (each within the scatter of the next, the first and the last beyond it).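

Taking the chloro group off altogether, something no earlier compound showed, gives a 1.5-fold lower number from compound 2 to compound 3 (0.17 log units; within the scatter) in this assay and so leaves 3-chlorophenyl and phenyl at this place indistinguishable. The same replacement made on the 4-chlorophenyl of compound 1 gives a 2.9-fold lower number from compound 1 to compound 3 (0.47 log units; beyond the scatter) and is the first step here to clear the scatter, though only modestly, so among these three compounds only the two ends of the series can be told apart. Nothing measured here explains why the numbers fall this way.

What the compounds shown leave open is whether any group on this ring can shift antiproliferative activity by more than a modest step, since only chloro and hydrogen appear there; an amine, a methoxy group or a carboxylic acid on the same carbon would be a much sharper test. From the compounds shown here alone, all three compounds also share the rest of their structure unchanged, so how much the other parts of the shared core contribute to the activity remains unknown.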